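Working notes: from compound 3 to compound 4

The source may report more compounds than this note shows. Statements on the series, on what has been measured and on what is new or still open speak of the compounds shown alone.

Measured so far in a functional assay on SH-SY5Y cells (Homo sapiens) for antiproliferative activity, read by MTT assay, with a stated time of 72 h; a higher number here means a weaker inhibitor, a lower number a stronger inhibitor
- compound 1 `COc1cc2c(Nc3ccc(C#N)cc3)ncnc2cc1OCCCN1CCCCC1CCO` gives > 100000 nM (a limit of the assay, not a number)
- compound 2 `COc1cc2c(Nc3ccc(C#N)cc3)ncnc2cc1OCCCN1CCC(c2ccccc2)CC1` gives 7770 nM
- compound 3 `COc1cc2c(Nc3ccc(C#N)cc3)ncnc2cc1OCCCN1CCC(N(C)C)CC1` gives 24300 nM

In this assay compound 3 at 24300 nM holds the higher of the two actual numbers, and compound 2 is its nearest neighbour. Compound 1 stays a limit (the limit of > 100000 nM in this assay, at which 1 of the 3 values shown sits) and not a number.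

The next structure is compound 4 `CCN1CCN(CCCOc2cc3ncnc(Nc4ccc(C#N)cc4)c3cc2OC)CC1` (4-ethylpiperazin-1-yl in place of 4-(dimethylamino)piperidin-1-yl on a saturated chain carbon, three bonds along the chain from an oxygen on an aromatic ring), with 4-ethylpiperazin-1-yl in place of 4-(dimethylamino)piperidin-1-yl on a saturated chain carbon, three bonds along the chain from an oxygen on an aromatic ring.

Two measured steps change this same place, and both start from the limit: an at least 12-fold lower number from compound 1 to compound 2 (1.10 log units; beyond the scatter) was large and an at least 4.1-fold lower number from compound 1 to compound 3 (0.61 log units; beyond the scatter) at least modest. The closest guide is the swap of phenyl for dimethylamino on a saturated ring carbon, where compound 3 came out with a 3.1-fold higher number from compound 2 to compound 3 (0.50 log units; beyond the scatter) as a modest change. Both groups in the new change hold a six-membered non-aromatic ring, so a step no larger than that one is expected, with a slight lean towards a lower number. The expected step is a 1.2-fold lower number from compound 3 to compound 4 (0.08 log units; within the scatter) in this assay as a working figure. The expected value for compound 4 is 20000 nM within an estimated range of 7000 nM to 60000 nM for now.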

Compound 4, half-maximal inhibitory concentration: 5440 nM
Compound 4: the middle estimate sits 3.7-fold (0.57 log units) above what was measured; measured number outside the range, below it.
By their numbers in this assay, from the lowest: compounds 4 and 2 (each within the scatter of the next); then compound 3. At a limit, above all of these: compound 1.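

In this assay, this place on a saturated chain carbon, three bonds along the chain from an oxygen on an aromatic ring, responds even to a swap between two closely matched groups: a 4.5-fold lower number from compound 3 to compound 4 (0.65 log units; beyond the scatter). Both groups hold a six-membered non-aromatic ring and have the same counts of donors and acceptors, so the difference lies in the ring's hetero atoms and in how the ring is substituted. Against the 4-phenylpiperidin-1-yl group the result is a 1.4-fold lower number from compound 2 to compound 4 (0.15 log units; within the scatter), so phenyl is not the only ring substituent that gives a number of this size, while the step of an at least 18-fold lower number from compound 1 to compound 4 (1.26 log units; beyond the scatter) gives only a bound, as its starting value is a limit and not a number: the limit of > 100000 nM in this assay, at which 1 of the 4 values shown sits.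

The compounds shown do not separate the extra ring hetero atom from the ethyl group, and a 4-methylpiperazin-1-yl or morpholin-4-yl group at the same place would bear on that. From the compounds shown here alone, whether the same order holds with a longer chain between the oxygen and the ring also stays open.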